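This account rests on a few compounds, and the source may have more. Where it says the series, first, only, none or still open, it means among the compounds named here.

Three compounds share one core and differ only in the chain carried on the oxygen on the aromatic ring. In a functional assay on RAW264.7 cells (Mus musculus) for inhibition, read by immunoassay, with a stated time of 12 h, tested at 30 uM (a lower number here means less inhibition, a higher number more inhibition at the concentration tested (going by the name of the read-out)), compound 1 `CC(C)CCOc1ccccc1C1CC(=O)c2ccccc2O1` gives 47.6%, compound 2 `CCCOc1ccccc1C1CC(=O)c2ccccc2O1` gives 45.7%, and compound 3 `C=CCOc1ccccc1C1CC(=O)c2ccccc2O1` gives 49.3%. The number for compound 3 is nominally the highest of the three, but a number 1.7 percentage points higher from compound 1 to compound 3 (within the scatter) and a number 3.6 percentage points higher from compound 2 to compound 3 (within the scatter) are both within the scatter, as is a number 1.9 percentage points lower from compound 1 to compound 2 (within the scatter), so the three cannot be ranked. Compound 4 `CC(C)=CCOc1ccccc1C1CC(=O)c2ccccc2O1` differs from compound 3 by 2-methylprop-1-en-1-yl in place of vinyl on a saturated chain carbon bound to an oxygen on an aromatic ring. Among the compounds with values here, every change at this place so far, whether vinyl replacing ethyl or vinyl replacing isobutyl, has stayed within the scatter, so for compound 4 no step beyond the scatter is expected, a number 1.3 percentage points lower from compound 3 to compound 4 (within the scatter). Compound 4 is therefore estimated at 48%, between 38% and 58%.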

Compound 4, a percentage reported as inhibition, at one concentration (the size of the read-out at that concentration, not a potency): 41.8%
Estimate against measurement, compound 4: 6.2 percentage points above; the range from low to high includes it.
By their numbers in this assay, from the lowest: compounds 4, 2, 1 and 3 (each within the scatter of the next).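

In this assay, 3-methylbut-2-en-1-yl in place of allyl gives the largest step yet seen at this position (a number 7.5 percentage points lower from compound 3 to compound 4 (within the scatter)), and even this stays within the scatter. The steps from the saturated chains read the same (a number 3.9 percentage points lower from compound 2 to compound 4 (within the scatter); a number 5.8 percentage points lower from compound 1 to compound 4 (within the scatter)), so these four chains, branched or unbranched, saturated or unsaturated, cannot be told apart here. Nothing available explains these numbers. Still open, on these data alone, is whether an amine or a carboxylic acid on this chain, or a much longer chain, would give a step beyond the scatter.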